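This account rests on a few compounds, and the source may have more. Where it says the series, first, only, none or still open, it means among the compounds named here.

Compound 1 `Cc1ccc(CS/C(=C/c2ccccc2F)C(=O)c2ccc(Cl)cc2)cc1` sits in the middle of three measured compounds in a functional assay on DU-145 cells (Homo sapiens) for inhibition, read by trypan blue exclusion, with a stated time of 96 h (on this read-out higher numbers stand for weaker inhibition of growth and lower numbers for stronger inhibition of growth), with a reading of 10000 nM. Compound 3 `Cc1ccc(S/C(=C/c2ccc(-c3ccccc3)cc2)C(=O)c2ccc(Cl)cc2)cc1` gives 50000 nM, a weaker result beyond the usual scatter, while compound 2 `Cc1ccc(S/C(=C/c2c[nH]c3ccc(Cl)cc23)C(=O)c2ccc(Cl)cc2)cc1` gives 1000 nM, a stronger result that also lies beyond the scatter. Compound 4 `Cc1ccc(CS/C(=C/c2ccc(N(C)C)cc2)C(=O)c2ccc(Cl)cc2)cc1` has not been measured; it differs from compound 1 by 4-(dimethylamino)phenyl in place of 2-fluorophenyl on a double-bonded chain carbon bound to a double-bonded chain carbon. Among the compounds with values here, nothing among the measured compounds isolates this exchange, so the direction can only be guessed from the shared core of compound 1. A step toward a somewhat lower number is expected from compound 1 to compound 4, of about a 2.0-fold lower number from compound 1 to compound 4 (0.30 log units; within the scatter), though it may not clear the scatter. Compound 4 is estimated at 5000 nM, within a range of 1500 nM to 20000 nM.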

Compound 4, concentration for 50% growth inhibition: > 100000 nM
Compound 4: no number, only a limit (the forecaster's own chance of this, stated with the estimate: 10%); at least 20-fold (1.30 log units) between middle value and limit.
By their numbers in this assay, from the lowest: compound 2; then compound 1; then compound 3. At a limit, above all of these: compound 4.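

Compound 4 gives no number in this assay, only a limit: the limit of > 100000 nM in this assay, at which 1 of the 4 values shown sits. The exchange of 2-fluorophenyl for 4-(dimethylamino)phenyl gives an at least 10-fold higher number from compound 1 to compound 4 (1.00 log units; beyond the scatter), so growth inhibition in this series responds strongly to the group at this position. The earlier compounds shown here could not show this, as no two of them differed in one place only.

Going by these compounds, the true size of the step stays open behind the limit. Also open, on these data alone, is whether a 4-aminophenyl or a 4-methoxyphenyl group here would keep the reading of compound 1 or lose it as well.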